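This account rests on a few compounds, and the source may have more. Where it says the series, first, only, none or still open, it means among the compounds named here.

Measured so far:
compound 1 `O=C(CI)NCCCNc1ncnc2c1ncn2[C@@H]1O[C@H](COP(=O)(O)OP(=O)(O)OP(=O)(O)O)[C@@H](O)[C@H]1O` — 0%
compound 2 `O=C(CI)NCCCCCCC(=O)NCCCNc1ncnc2c1ncn2[C@@H]1O[C@H](COP(=O)(O)OP(=O)(O)OP(=O)(O)O)[C@@H](O)[C@H]1O` — 0%
compound 3 `Nc1ncnc2c1nc(NCCNC(=O)CI)n2[C@@H]1O[C@H](COP(=O)(O)OP(=O)(O)OP(=O)(O)O)[C@@H](O)[C@H]1O` — 0%

In an assay on isolated protein for inhibition of hexokinase-3 (Rattus norvegicus), with a stated time of 6 h, tested at 10 mM (on this read-out lower numbers stand for less inhibition and higher numbers for more inhibition at the one concentration tested (going by the name of the read-out)), compound 1 gives 0%, level with compound 2 and compound 3 at the digits shown. Compound 4 `O=C(I)NCC(=O)NCCCCCCNc1ncnc2c1ncn2[C@@H]1O[C@H](COP(=O)(O)OP(=O)(O)OP(=O)(O)O)[C@@H](O)[C@H]1O` differs from compound 1 by a group of 11 heavy atoms (6 carbon, 2 nitrogen, 2 oxygen, 1 iodine; no ring) in place of a group of 5 heavy atoms (2 carbon, 1 nitrogen, 1 oxygen, 1 iodine; no ring), on a saturated chain carbon, three bonds along the chain from a nitrogen on an aromatic ring. Among the measured compounds shown here, the only measured step that alters one place, no change at the digits printed from compound 1 to compound 2 (within the scatter), also enlarges the group on a saturated chain carbon bound to a carbonyl carbon and stays within the scatter; compound 3 carries its own chain elsewhere and reads the same. No measured change in this series has moved the read-out. Compound 4 is therefore expected to give 0%, in a range from -8% to 10%, so that the estimated step of no change at the digits printed from compound 1 to compound 4 (within the scatter) is none beyond the scatter.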

Compound 4, a percentage reported as inhibition, at one concentration (the size of the read-out at that concentration, not a potency): 0%
Compound 4: the middle estimate sits on the measured number at the digits printed; measured number inside the range.
By their numbers in this assay, from the lowest: compounds 1, 2, 3 and 4 (each within the scatter of the next).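

In this assay, replacing ((iodomethyl)carbonyl)amino with the group of 11 heavy atoms gives no change at the digits printed from compound 1 to compound 4 (within the scatter). Among the compounds shown here, the change at this second place, on a saturated chain carbon, three bonds along the chain from a nitrogen on an aromatic ring, therefore separates no compound from the others, so the read-out still gives no handle on the series. No available evidence bears on this result.

Still open, from the compounds shown here alone, is whether any group at this place gives inhibition beyond the scatter, for example an amine, a carboxylic acid or a longer chain.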